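The source may report more compounds than this note shows. Statements on the series, on what has been measured and on what is new or still open speak of the compounds shown alone.

Of the compounds shown here, two have so far been measured in an assay on HEK-293T cells for inhibition of phospholipase A and acyltransferase 2 (Homo sapiens), with stated times of 30 min and 20 min; a higher number here means a weaker inhibitor, a lower number a stronger inhibitor. Compound 1, with the structure `O=C(CCc1ccccc1)C(F)(F)C(=O)NCc1ccccc1`, gives a reading of > 10000 nM, which is a limit of the assay rather than a number. Compound 2, with the structure `CN(C)C(=O)C(=O)CCc1ccc(Cl)cc1`, likewise gives > 10000 nM, again a limit and not a measured number. Both readings sit at the limit of > 10000 nM in this assay, at which 2 of the 2 values shown sit, so compound 2 stands at the weak end of what this assay can report, and no ordering between compound 1 and compound 2 can be read from these two readings.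

Compound 3 has the structure `O=C(CCc1ccc(Cl)cc1)C(=O)N1CCCC1`. It differs from compound 2 in one place: pyrrolidin-1-yl in place of dimethylamino on a carbonyl carbon. Within the data shown here, no pair of measured compounds shows what such a swap does, so there is no measured step to lean on. For compound 3 the step that the limit leaves unreadable from compound 2 to compound 3 is expected to be small or none beyond the scatter. The estimate for compound 3 in this assay is 12000 nM, within a range from 3000 nM to 50000 nM, and a reading that is once more only a limit would be unsurprising.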

Compound 3, half-maximal inhibitory concentration: > 10000 nM
Compound 3 gave a limit, no number; the forecaster's own chance of this, stated with the estimate: 75%; the middle value is on the limit's open side.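

In this assay compound 3 gives > 10000 nM, a limit and not a number. Among these compounds, compound 2 also gives only a limit, so no step between compound 2 and compound 3 can be read, and every reading stands at the same place: the limit of > 10000 nM in this assay, at which 3 of the 3 values shown sit. The compounds shown leave open whether pyrrolidin-1-yl in place of dimethylamino on a carbonyl carbon changes inhibition at all.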